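The compounds below may be only part of what the source reports. "The series", "measured", "known", "first", "only" and "open" are said of these compounds alone.

Measured compounds and their values:

Compound 1, `Cc1cc(=O)oc2cc(OCc3cn(-c4ccc(F)cc4F)nn3)ccc12` — > 100 ug/mL
Compound 2, `CC(=O)Nc1ccc(-n2cc(COc3ccc4c(C)cc(=O)oc4c3)nn2)cc1` — > 100 ug/mL
Compound 3, `COc1ccc(-n2cc(COc3ccc4c(C)cc(=O)oc4c3)nn2)c(OC)c1` — > 100 ug/mL

All three were tested in an ADME assay on Huh-7 cells (Homo sapiens) for cytotoxicity, read by MTT assay, with a stated time of 72 h; a higher number here means that more compound is tolerated, a lower number that less compound is tolerated. For compound 1 the result > 100 ug/mL is a limit of the assay rather than a measured number. The same holds for compound 2, whose result > 100 ug/mL is also a limit. Compound 3 likewise gives only a limit, > 100 ug/mL. So compound 1 does not stand at a particular point among these three; it sits at the limit of > 100 ug/mL in this assay, at which 3 of the 3 values shown sit, together with the other two, and no compound among them can be ranked above or below another.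

Compound 4, `Cc1cc(=O)oc2cc(OCc3cn(Cc4ccccc4)nn3)ccc12`, shares the same core and differs from compound 1 at one spot: benzyl in place of 2,4-difluorophenyl on an aromatic nitrogen. For the measured compounds named here, no pair of measured compounds differs in only one place, so no measured step exists to lean on. Going by the values given here, with every value so far resting at the same limit, the expected change in this assay from compound 1 to compound 4 is none beyond the usual scatter, that is a step that the limit leaves unreadable from compound 1 to compound 4. The estimate for compound 4 in this assay is therefore 150 ug/mL, with a range from 60 ug/mL to 400 ug/mL, and most likely the assay will again report only a limit.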

Compound 4, half-maximal cytotoxic concentration: > 100 ug/mL
Compound 4: a limit, no number; the forecaster's own chance of this, stated with the estimate: 80%; the middle value lies beyond the limit too.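

In this assay compound 4 gives > 100 ug/mL, which is a limit and not a number. Compound 1 also gives only a limit, so no step from compound 1 to compound 4 can be read: the limit of > 100 ug/mL in this assay, at which 4 of the 4 values shown sit.

The compounds shown leave open the actual half-maximal cytotoxic concentration of each, and so whether any change on the shared core shifts it.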